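Swapping Chloro for Trifluoromethyl in a Cytotoxicity Series

The compounds below may be only part of what the source reports. "The series", "measured", "known", "first", "only" and "open" are said of these compounds alone.

Within the data shown here, compound 2 `O=S(=O)(c1ccc(Br)cc1)c1nc2ccccc2nc1Nc1ccc(Cl)cc1` gives 7460 nM in a functional assay on PC-3 cells (Homo sapiens) for cytotoxicity, read by MTT assay, with a stated time of 72 h (a higher number here means a weaker inhibitor, a lower number a stronger inhibitor), the highest of the two numbers measured so far; its nearest neighbour, compound 1 `Nc1ccc(Nc2nc3ccccc3nc2S(=O)(=O)c2ccc(Br)cc2)cc1`, gives 2330 nM in this assay. Among the measured compounds shown here, the one measured step, a 3.2-fold higher number from compound 1 to compound 2 (0.51 log units; beyond the scatter), came from putting chloro in place of amino and points to a weaker inhibitor. Compound 3 `O=S(=O)(c1ccc(Br)cc1)c1nc2ccccc2nc1Nc1ccc(C(F)(F)F)cc1` differs from compound 2 by trifluoromethyl in place of chloro on an aromatic carbon, sitting on an aromatic carbon of a six-membered aromatic ring of carbon only, para to a large group. For the measured compounds named here, no measured step involves a trifluoromethyl group, so the earlier step bears on this change only loosely: it shows that a swap at this place can shift the number modestly, but it gives no direction for this swap. A change within the scatter, or a small further rise, is expected, which is a 1.2-fold higher number from compound 2 to compound 3 (0.08 log units; within the scatter). Compound 3 is therefore estimated at 9000 nM, most likely between 3500 nM and 25000 nM.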

Compound 3, half-maximal inhibitory concentration: 4150 nM
The estimate for compound 3 lay 2.2-fold (0.34 log units) above the measured number; the measured number falls inside the stated range.
By their numbers in this assay, from the lowest: compounds 1, 3 and 2 (each within the scatter of the next, the first and the last beyond it).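

Putting trifluoromethyl in place of chloro on this aromatic carbon, para to a large group, gives a 1.8-fold lower number from compound 2 to compound 3 (0.25 log units; within the scatter) in this assay, so going from one heavy atom to four at this place does not shift the number beyond the scatter. Trifluoromethyl in place of amino gives a 1.8-fold higher number from compound 1 to compound 3 (0.25 log units; within the scatter), which leaves compound 3 within the scatter of both neighbours, although the earlier step, a 3.2-fold higher number from compound 1 to compound 2 (0.51 log units; beyond the scatter), lies beyond it. No evidence is available on why these numbers fall as they do.

Still open, as far as these compounds go, is how other groups at this place, such as a methoxy group, a carboxylic acid or a longer alkyl chain, would compare. The compounds shown also leave open whether these swaps would read the same with changes elsewhere on the shared core.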